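A few compounds are considered here, and "the series" means these few. Any claim that something is new, unique, unknown or untested is made for them only; others in the source may bear on it.

Measured so far:
- compound 1 `C=CC[C@H]1C[C@]2([C@@H](C)Cc3ccc(OC)cc3)OCOC2=CC1=O` — 20 nM in a functional assay on M14 cells (Homo sapiens) for antiproliferative activity, with a stated time of 72 h; on this read-out higher numbers stand for weaker inhibition and lower numbers for stronger inhibition
- compound 2 `C=CC[C@H]1C[C@]2(C(C)Cc3ccc(OCC)cc3)OCOC2=CC1=O` — 650 nM in this assay

Of the two numbers measured, compound 2 stands highest in this assay; the nearest value belongs to compound 1, whose number lies well below it, a gap beyond the usual scatter. Among the measured compounds shown here, the two compounds differ in more than one place, so their values are simply set side by side here and no step is drawn between them.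

Compound 3 `C=CC[C@H]1C[C@]2(C(C)Cc3ccc(F)cc3)OCOC2=CC1=O` has not yet been tested in this assay. It differs from compound 2 in one place: fluoro in place of ethoxy on an aromatic carbon. For the measured compounds named here, no step of this kind has been measured, so the expected change from compound 2 to compound 3, namely a 1.6-fold lower number from compound 2 to compound 3 (0.21 log units; within the scatter), is small and within the scatter, with only a slight lean toward a lower number. On that basis compound 3 is estimated at 400 nM in this assay, within a range of 80 nM to 2500 nM.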

Compound 3, half-maximal inhibitory concentration: > 20000 nM
Compound 3 ended at the assay's limit; the forecaster's own chance of this, stated with the estimate: 5%; middle value at least 50-fold (1.69 log units) from the limit.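

Among the compounds shown here, the step of an at least 30-fold higher number from compound 2 to compound 3 (1.48 log units; beyond the scatter) is the first comparison that changes only this aromatic carbon, para to a large group, since compound 1 and compound 2 differ in more than one place. It shows that, with the rest of compound 2 kept, the group at this carbon strongly affects the read-out, and fluoro does not keep the activity that ethoxy gives. Compound 3 gives > 20000 nM in this assay, which is a limit of the assay and not a number, so the true size of the step stays unknown: the limit of > 20000 nM in this assay, at which 1 of the 3 values shown sits.

The compounds shown do not tell whether the oxygen or the two carbons of ethoxy matter more at this carbon. On these data alone, how a hydroxy group, an amine or a longer chain such as butoxy would fare there also remains open.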